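The source may hold more compounds than are shown below. What is called first, only, known or untested is meant among the compounds shown, and "the series" means these compounds.

Compound 1 `COc1ccc(Nc2cc(C3CCCCC3)oc(=O)c2)cc1` was tested in a functional assay on DU-145 cells (Homo sapiens) for cytotoxicity, read by MTT assay, with a stated time of 72 h (on this read-out higher numbers stand for an effect only at larger amounts of compound and lower numbers for an effect already at smaller amounts), and gives 8.61 uM. Its number sits far from that of compound 2 `O=c1cc(Nc2ccccc2)cc(-c2ccccc2)o1`, which in this assay gives 0.098 uM, and close to that of compound 3 `O=c1cc(NC2CCCCC2)cc(-c2ccccc2)o1`, which in this assay gives 7.47 uM; the gap between compound 1 and compound 3 lies within the usual scatter, whereas compound 2 stands well apart from both. Among the measured compounds shown here, the only single-change step among the three, a 76-fold higher number from compound 2 to compound 3 (1.88 log units; beyond the scatter), concerns the group on the nitrogen and leaves the group on the aromatic carbon untouched.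

Compound 4 `CCCCCc1cc(Nc2ccc(OC)cc2)cc(=O)o1` differs from compound 1 in that other place: pentyl in place of cyclohexyl on an aromatic carbon. For the measured compounds named here, no measured pair among the three compounds alters the group on this carbon, so the step from compound 1 to compound 4 has no direct precedent, and the one measured step bears on a different position. With nothing to point in either direction, the expectation is for a number close to that of compound 1, an expected step of a 1.1-fold lower number from compound 1 to compound 4 (0.03 log units; within the scatter), which is within the scatter. Compound 4 is therefore estimated at 8 uM, with a range from 3 uM to 25 uM.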

Compound 4, concentration for half-maximal effect: 5.94 uM
The estimate for compound 4 lay 1.3-fold (0.13 log units) above the measured number, within the range that was stated.
By their numbers in this assay, from the lowest: compound 2; then compounds 4, 3 and 1 (each within the scatter of the next).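

Among the compounds shown here, the step of a 1.4-fold lower number from compound 1 to compound 4 (0.16 log units; within the scatter) is the first direct reading of this position, on an aromatic carbon next to the ring oxygen, and in this assay it shows that replacing the cyclohexyl ring with an open pentyl chain, with the group on the nitrogen held fixed, leaves the number within the scatter. For the compounds shown here, this contrasts with the only earlier single-change step, a 76-fold higher number from compound 2 to compound 3 (1.88 log units; beyond the scatter), which lies beyond the scatter and concerns the group on the nitrogen, although that step was read with a phenyl rather than a cyclohexyl or pentyl group on the aromatic carbon. No measurement shown here offers an explanation for the result at this position.

The compounds shown leave open what a short methyl group, a longer chain such as octyl, or a pentyl chain ending in an amine or a carboxylic acid would do on this carbon. They also leave open whether exchanging cyclohexyl for pentyl would stay as small with a different group on the nitrogen, such as the plain phenyl of compound 2.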